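Bromo for chloro on the ring of compound 2

This account rests on a few compounds, and the source may have more. Where it says the series, first, only, none or still open, it means among the compounds named here.

The measured compounds and their numbers:
Compound 1, `Cc1ccc(S(=O)(=O)N2CCC(Cl)=CC2CC(C)C)cc1`, in a functional assay on A2780 cells (Homo sapiens) for antiproliferative activity, read by sulforhodamine B assay, with a stated time of 48 h (on this read-out lower numbers stand for stronger inhibition of growth and higher numbers for weaker inhibition of growth), gives 35000 nM.
Compound 2, `Cc1ccc(S(=O)(=O)N2CCC(Cl)=CC2C2CCCCC2)cc1`, gives 39000 nM.
Compound 3, `Cc1ccc(S(=O)(=O)N2CCC(Cl)=CC2c2ccccc2)cc1`, gives 17000 nM.

Compound 2 holds the highest of the three numbers, so it is the weakest inhibitor of growth among them. Its nearest neighbour is compound 1: the step of a 1.1-fold higher number from compound 1 to compound 2 (0.05 log units; within the scatter) lies within the scatter. Its furthest neighbour is compound 3: a 2.3-fold lower number from compound 2 to compound 3 (0.36 log units; beyond the scatter), a modest step beyond the scatter.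

The unmeasured compound 4 is `Cc1ccc(S(=O)(=O)N2CCC(Br)=CC2C2CCCCC2)cc1`. It differs from compound 2 in one place: bromo in place of chloro on a double-bonded ring carbon. None of the three measured steps bears on this change; each of them alters the group on the saturated ring carbon, and the halogen on the double-bonded carbon stays chloro throughout. There is therefore no measured guidance, and the plain expectation is that compound 4 behaves like compound 2, with no step beyond the scatter, estimated as no change at the digits printed from compound 2 to compound 4 (within the scatter). Compound 4 is estimated at 39000 nM, in a range from 18000 nM to 85000 nM.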

Compound 4, concentration for 50% growth inhibition: 44000 nM
The estimate for compound 4 lay 1.1-fold (0.05 log units) below the measured number; measured number inside the range.
By their numbers in this assay, from the lowest: compound 3; then compounds 1, 2 and 4 (each within the scatter of the next).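

The earlier compounds shown here all carry chloro on the double-bonded ring carbon, so they said nothing about how this position responds to a change of halogen. In this assay, bromo in place of chloro gives a step within the scatter (a 1.1-fold higher number from compound 2 to compound 4 (0.05 log units; within the scatter)), so with a cyclohexyl group on the saturated ring carbon, the two halogens read alike. The data shown offer no explanation for this result.

As far as these compounds go, this is a single pair, so it remains open whether the same swap would read alike in compound 3, which carries a phenyl group in place of the cyclohexyl group. Also open, from the compounds shown here alone, is how a group other than a halogen, such as an amine, a methoxy group or a nitrile, would read on the double-bonded ring carbon.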